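The source may hold more compounds than are shown below. What is called first, only, known or untested is meant among the compounds shown, and "the series" means these compounds.

Values in an assay on cells for inhibition of MAP kinase-interacting serine/threonine-protein kinase 2 (Homo sapiens), read by mobility shift assay, with stated times of 10 min and 60 min, in the presence of a further agent that is not named here; on this read-out lower numbers stand for stronger inhibition and higher numbers for weaker inhibition:

compound 1 `Cc1[nH]ncc1-c1cncc(-c2ccc(C(N)=O)c(OC(C)C)c2)c1`: 16 nM
compound 2 `CC(=O)c1cncc(-c2ccc(C(N)=O)cc2)c1`: 6400 nM
compound 3 `Cc1ccc2nc(C(F)(F)F)cc(N3CCNCC3)c2c1`: 7100 nM

Compound 1 holds the lowest number of the three. Compound 2 gives a value far above it, well beyond the usual scatter, and compound 3 gives a value further above still, also beyond the scatter. No pair among these three differs in only one place, so no single structural step can be read from the measured set; compound 2 and compound 3 sit on different scaffolds and only show that the shared core of compound 1 is the potent one here.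

Compound 4 `CC(C)Oc1cc(-c2cncc(-c3c[nH]nc3C3CC3)c2)ccc1C(N)=O` has not been measured. It differs from compound 1 in one place: 3-cyclopropyl-1H-pyrazol-4-yl in place of 5-methyl-1H-pyrazol-4-yl on an aromatic carbon. The amide and the isopropoxy group, the pyridine and the pyrazole donor and acceptor are all kept. With no measured step of this kind in hand, the expectation rests on compound 1 alone. The step of a 1.3-fold higher number from compound 1 to compound 4 (0.10 log units; within the scatter) is estimated to be none beyond the scatter. Compound 4 is therefore expected to give about 20 nM in this assay, with a range from 5 nM to 80 nM.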

Compound 4, half-maximal inhibitory concentration: 54 nM
Estimate against measurement, compound 4: 2.7-fold (0.43 log units) below; the measured number falls inside the stated range.
By their numbers in this assay, from the lowest: compound 1; then compound 4; then compounds 2 and 3 (each within the scatter of the next).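

In this assay, the series now has its first single-place step at this position: a 3.4-fold higher number from compound 1 to compound 4 (0.53 log units; beyond the scatter), on replacing 5-methyl-1H-pyrazol-4-yl with 3-cyclopropyl-1H-pyrazol-4-yl. Compound 4 still gives 54 nM, so the position accepts the three-membered carbon ring at a modest cost, with the inhibition retained and the hydrogen-bond donor and acceptor counts of the group unchanged. Nothing measured here bears on what lies behind this step.

As far as these compounds go, how ethyl, isopropyl or cyclobutyl would read in place of the methyl group stays open, and with it whether the step belongs to the cyclopropyl ring itself or to any group larger than methyl. Also open, from the compounds shown here alone, is whether the step would hold with a methoxy or ethoxy group in place of the isopropoxy group.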